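Compound 3 to compound 4: an ester on the side chain

This account rests on a few compounds, and the source may have more. Where it says the series, first, only, none or still open, it means among the compounds named here.

Values in a functional assay on SW1573 cells (Homo sapiens) for antiproliferative activity, read by sulforhodamine B assay, with a stated time of 48 h (on this read-out lower numbers stand for stronger inhibition of growth and higher numbers for weaker inhibition of growth), follow.
compound 1 `CC(C)(C)[Si](C)(C)O[C@H]1CCCO[C@@H]1CO` gives > 100000 nM (a limit of the assay)
compound 2 `CC(C)(C)[Si](C)(C)O[C@@H]1CCCO[C@@H]1COCC(=O)OCc1ccccc1` gives 29000 nM
compound 3 `C=CCOC[C@H]1OCCC[C@H]1O[Si](C)(C)C(C)(C)C` gives 18000 nM

Within the data shown here, compound 3 at 18000 nM and compound 2 at 29000 nM lie within the scatter of each other, and these are the only two true numbers in the set. Compound 4 `COC(=O)CCOC[C@H]1OCCC[C@H]1O[Si](C)(C)C(C)(C)C` has (methoxycarbonyl)methyl in place of vinyl on a saturated chain carbon bound to an oxygen on a saturated carbon, which reads as allyloxy to 2-(methoxycarbonyl)ethoxy. Among the measured compounds shown here, no measured pair isolates this change. The nearest guide is compound 2, which carries an ester and gives 29000 nM in this assay without leaving the scatter of the allyl ether. The expected move is a 1.8-fold higher number from compound 3 to compound 4 (0.25 log units; within the scatter) as a small shift toward weaker inhibition of growth, about the size of the scatter. Compound 4 is estimated at 32000 nM with 14000 nM to 80000 nM as its expected range.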

Compound 4, concentration for 50% growth inhibition: > 100000 nM
Compound 4: no number, only a limit; the forecaster's own chance of this, stated with the estimate: 20%; at least 3.1-fold (0.49 log units) between middle value and limit.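

Placing (methoxycarbonyl)methyl in place of vinyl on a saturated chain carbon bound to an oxygen on a saturated carbon gives the first readable step of the series in this assay: an at least 5.5-fold higher number from compound 3 to compound 4 (0.74 log units; beyond the scatter). The chain at this position therefore matters to growth inhibition, and the change does not stay within the scatter. Compound 4 gives > 100000 nM, which is a limit and not a number, so the step has no upper size: the limit of > 100000 nM in this assay, at which 2 of the 4 values shown sit.

From the compounds shown here alone, whether the ester itself or the extra chain length drives this step stays open. A carboxylic acid, an amide or a plain butyl ether on this chain could separate the two.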